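The source may report more compounds than this note shows. Statements on the series, on what has been measured and on what is new or still open speak of the compounds shown alone.

Compound 2 `CNc1nc2c(-c3ccnc(OC)c3)cnn2cc1OC` gives 310 nM in an assay on isolated protein for inhibition of activin receptor type-2A (Homo sapiens), read by 33P incorporation, with a stated time of 20 min, in the presence of a further agent that is not named here (a lower number here means a stronger inhibitor, a higher number a weaker inhibitor), the lower of the two numbers recorded so far. Compound 1 `COc1cc(-c2cnn3cc(OC)c(-c4cnn(C)c4)nc23)ccn1` gives 530 nM in this assay, and the step of a 1.7-fold lower number from compound 1 to compound 2 (0.23 log units; within the scatter) separates these two compounds only within the scatter. Compound 3 `COc1cc(-c2cnn3cc(OC)c(C(C)C)nc23)ccn1` differs from compound 2 by isopropyl in place of methylamino on an aromatic carbon. Going by the values given here, no measured step covers this exchange: the only step on record, a 1.7-fold lower number from compound 1 to compound 2 (0.23 log units; within the scatter), replaces a different group on that aromatic carbon, and it was small. Among the compounds with values here, with that as the only guide, a step from compound 2 to compound 3 within the scatter, or a modest move toward a higher number, is expected, namely a 1.6-fold higher number from compound 2 to compound 3 (0.21 log units; within the scatter). Compound 3 is therefore estimated at 500 nM in this assay, with a range expected from 150 nM to 1600 nM.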

Compound 3, half-maximal inhibitory concentration: 3800 nM
Estimate against measurement, compound 3: 7.6-fold (0.88 log units) below; the whole stated range lies below it.
By their numbers in this assay, from the lowest: compounds 2 and 1 (each within the scatter of the next); then compound 3.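

Until this result, the aromatic carbon next to the ring nitrogen had shown only a step within the scatter, and isopropyl is the first group there to go beyond it: a 12-fold higher number from compound 2 to compound 3 (1.09 log units; beyond the scatter) in this assay, and a 7.2-fold higher number from compound 1 to compound 3 (0.86 log units; beyond the scatter). The number at this position therefore depends on the group it carries, with methylamino and 1-methyl-1H-pyrazol-4-yl within the scatter of each other and isopropyl apart from both. Methylamino counts one hydrogen-bond donor and one acceptor where isopropyl counts neither, but nothing on hand explains the rise in the number.

The compounds shown leave open whether the hydrogen on the methylamino nitrogen matters, which a dimethylamino group at this carbon would test. They also leave open how a methyl or an ethyl group would compare with isopropyl there.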